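Taking the chloro off compound 1

This account rests on a few compounds, and the source may have more. Where it says the series, first, only, none or still open, it means among the compounds named here.

compound 1 `CC(C)COc1ncc(-c2cn(C)c3cc(C(=O)NS(=O)(=O)C4CC4)c(F)cc23)cc1Cl` gives 335 nm/s as measured
compound 2 `CC(C)COc1ccc(-c2nn(C)c3cc(C(=O)NS(=O)(=O)C4CC4)c(F)cc23)cn1` gives 762 nm/s as measured

Both numbers come from an ADME assay for permeability, using PAMPA, at pH 5.5 (on this read-out lower numbers stand for lower permeability and higher numbers for higher permeability), where compound 1 stands lowest of the two, and the gap up to compound 2 lies beyond the usual scatter. Compound 3 `CC(C)COc1ccc(-c2cn(C)c3cc(C(=O)NS(=O)(=O)C4CC4)c(F)cc23)cn1` has not yet been measured. It follows from compound 1 through one change, hydrogen in place of chloro on an aromatic carbon and the core stays the same. For the measured compounds named here, no measured step shows this change directly, so the expectation remains loose. Going by the values given here, compound 2 at 762 nm/s gives the only other number, and the middle of the estimate is kept under it. The expected change is a modest rise a 1.6-fold higher number from compound 1 to compound 3 (0.19 log units; within the scatter) in this assay and its direction is uncertain. The estimate for compound 3 stands at 520 nm/s (expected range 270 nm/s to 950 nm/s).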

Compound 3, apparent permeability: 851 nm/s
Beside the measured number, compound 3's estimate is 1.6-fold (0.21 log units) below it, within the range that was stated.
By their numbers in this assay, from the lowest: compound 1; then compounds 2 and 3 (each within the scatter of the next).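

In this assay hydrogen in place of chloro on an aromatic carbon, ortho to an isobutoxy group, gives a 2.5-fold higher number from compound 1 to compound 3 (0.40 log units; beyond the scatter) as a change in one place. Compound 1 and compound 2 differ in more than one place, so their gap could not be tied to any single position, whereas this step ties a change beyond the scatter to the chloro position alone. Nothing measured here explains why the number moves at this position.

From the compounds shown here alone, only chloro and hydrogen appear at this position, so it remains open whether a fluoro, a methoxy or a nitrile there would fall nearer compound 1 or compound 3. Going by these compounds, it also remains open whether the same swap would give a similar step on the core of compound 2.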